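Chloro on the phenyl ring: compound 2 to compound 4

A few compounds are considered here, and "the series" means these few. Any claim that something is new, unique, unknown or untested is made for them only; others in the source may bear on it.

In a functional assay on NCI-H460 cells (Homo sapiens) for inhibition, read by MTT assay, with a stated time of 24 h, tested at 100 ug/mL (a lower number here means less inhibition of growth, a higher number more inhibition of growth at the concentration tested), compound 2 `O=C(CCCCC(S)CCS)Nc1ccccc1` gives 25.4%, the second highest of three numbers. Compound 1 `O=C(CCCCC(S)CCS)NO` gives 43.7%. Compound 3 `O=C(CCCCC(S)CCS)Nc1ccccc1Cl` gives 12.1%.

The unmeasured compound 4 `O=C(CCCCC(S)CCS)Nc1cccc(Cl)c1` arises from compound 2 by chloro in place of hydrogen on an aromatic carbon. Among the compounds with values here, the closest precedent is a number 13.3 percentage points lower from compound 2 to compound 3 (beyond the scatter), also chloro in place of hydrogen on an aromatic carbon. The other measured step, a number 18.3 percentage points lower from compound 1 to compound 2 (beyond the scatter), concerns the amide-type nitrogen and bears on this change only indirectly. The data do not show how much the place of the chloro matters, so the range stays wide. A modest fall is expected, a number 8.4 percentage points lower from compound 2 to compound 4 (within the scatter). Compound 4 is estimated at 17%, within an expected range of 6% to 30%.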

Compound 4, percent growth inhibition at one concentration: 24.8%
The estimate for compound 4 lay 7.8 percentage points below the measured number, and the stated range covers the measured number.
By their numbers in this assay, from the lowest: compound 3; then compounds 4 and 2 (each within the scatter of the next); then compound 1.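

In this assay, chloro on an aromatic carbon meta to a large group leaves the number essentially unchanged, with a number 0.6 percentage points lower from compound 2 to compound 4 (within the scatter). The same exchange at the chloro place of compound 3 gave a number 13.3 percentage points lower from compound 2 to compound 3 (beyond the scatter), so within these compounds the fall follows the place of the chloro and not its mere presence on the ring. Nothing available here explains this difference.

Open, from the compounds shown here alone, is whether an amine or a methoxy group on this carbon would match chloro. Also open, going by these compounds, is whether a carboxylic acid there would shift the number beyond the scatter.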